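This account rests on a few compounds, and the source may have more. Where it says the series, first, only, none or still open, it means among the compounds named here.

Series of thiosemicarbazides from the shared core. Compound 1 `CC1=CC[C@H](C(C)(C)NC(=S)NN)CC1` carries no substituent on the terminal nitrogen, and in a functional assay on UACC-62 cells (Homo sapiens) for inhibition, read by sulforhodamine B assay, with a stated time of 48 h (on this read-out higher numbers stand for weaker inhibition of growth and lower numbers for stronger inhibition of growth), compound 1 gives "not determined" (no result reported). Going by the values given here, compound 2 `CC1=CC[C@H](C(C)(C)NC(=S)N/N=C/c2ccc(Cl)cc2)CC1` is the only member with a number: in this assay compound 2 gives 11200 nM. Compound 3 `CC1=CC[C@H](C(C)(C)NC(=S)N/N=C/c2ccco2)CC1` differs in one place, (furan-2-yl in place of 4-chlorophenyl on a carbon with a double bond to nitrogen). Among the compounds with values here, no measured step links a pair of this kind, so the expectation rests on compound 2 alone; a small step toward weaker inhibition, not clearly beyond the scatter, is expected, a 1.4-fold higher number from compound 2 to compound 3 (0.15 log units; within the scatter). For compound 3 the estimate is 16000 nM, expected between 5000 nM and 50000 nM.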

Compound 3, concentration for 50% growth inhibition: 10700 nM
For compound 3 the middle estimate is 1.5-fold (0.17 log units) above the measured one; measured number inside the range.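

At the position on a carbon with a double bond to nitrogen, furan-2-yl in place of 4-chlorophenyl gives a 1.0-fold lower number from compound 2 to compound 3 (0.02 log units; within the scatter) in this assay. Growth inhibition therefore holds across this swap, from a six-membered aromatic ring of carbon only bearing chlorine to a five-membered aromatic ring with 1 hetero atom. Nothing on hand offers a reason for this flat step. Still open, from the compounds shown here alone, is whether a group without an aromatic ring, such as cyclohexyl or a longer alkyl chain, keeps this level. Equally open, going by these compounds, is the outcome with a carboxylic acid or an amine on the phenyl ring.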